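Compound 4, a 2-Methoxyphenyl Analogue of Compound 2

A few compounds are considered here, and "the series" means these few. Any claim that something is new, unique, unknown or untested is made for them only; others in the source may bear on it.

Compound 2 `O=C(/C=C/c1ccc(Br)cc1)Nc1ccc2ncnc(Nc3cccc(Br)c3)c2c1` gives the highest number of the three measured compounds, with 15.3 ug/mL in a functional assay on A549 cells (Homo sapiens) for antiproliferative activity, read by MTT assay, with a stated time of 48 h; on this read-out higher numbers stand for weaker inhibition and lower numbers for stronger inhibition. Compound 1 `O=C(/C=C/c1ccccc1Cl)Nc1ccc2ncnc(Nc3cccc(Br)c3)c2c1` gives 6.63 ug/mL and compound 3 `COc1ccc(/C=C/C(=O)Nc2ccc3ncnc(Nc4cccc(Br)c4)c3c2)cc1` gives 3.36 ug/mL. Compound 4 `COc1ccccc1/C=C/C(=O)Nc1ccc2ncnc(Nc3cccc(Br)c3)c2c1` is compound 2 with 2-methoxyphenyl in place of 4-bromophenyl on a double-bonded chain carbon bound to a double-bonded chain carbon. Within the data shown here, two measured steps bear on this change. Putting methoxy in place of bromo gave a 4.6-fold lower number from compound 2 to compound 3 (0.66 log units; beyond the scatter). The step of a 2.3-fold higher number from compound 1 to compound 2 (0.36 log units; beyond the scatter) shows that the reverse move, from a 4-bromophenyl to a 2-chlorophenyl, also lowers the number. Both point the same way, so a lower number beyond the scatter is expected for compound 4, around a 3.4-fold lower number from compound 2 to compound 4 (0.53 log units; beyond the scatter). Compound 4 is therefore estimated at 4.5 ug/mL, with a range from 2 ug/mL to 10 ug/mL.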

Compound 4, half-maximal inhibitory concentration: 3.55 ug/mL
The estimate for compound 4 lay 1.3-fold (0.10 log units) above the measured number; the range from low to high includes it.
By their numbers in this assay, from the lowest: compounds 3, 4 and 1 (each within the scatter of the next); then compound 2.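

In this assay, the step with a 4.3-fold lower number from compound 2 to compound 4 (0.63 log units; beyond the scatter) shows that the drop seen with 4-methoxyphenyl in place of 4-bromophenyl also appears with 2-methoxyphenyl. With a 1.1-fold higher number from compound 3 to compound 4 (0.02 log units; within the scatter) in hand, the two methoxyphenyl groups cannot be told apart here, and a 1.9-fold lower number from compound 1 to compound 4 (0.27 log units; within the scatter) leaves 2-methoxyphenyl and 2-chlorophenyl equally unseparated. No evidence is available to explain these numbers. The compounds shown leave open whether an amine or a carboxylic acid in place of the methoxy would keep the number as low as in compound 4.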